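The compounds below may be only part of what the source reports. "The series", "measured", "known", "first", "only" and "open" are said of these compounds alone.

Measured so far:
compound 1 `O=C(NCc1ccc(S(=O)(=O)c2ccccc2)cc1)c1cc2ncccc2s1` — 1.6%
compound 2 `Cn1c(C(=O)NCc2ccc(S(=O)(=O)c3ccccc3)cc2)cc2ccncc21` — "below limit of detection" (no number reported)

In an ADME assay on microsomes from liver (Mus musculus) for metabolic stability, read by LC-MS, with a stated time of 30 min, tested at 1 uM (a higher number here means that more of the compound is left, a lower number that less of the compound is left), compound 1 gives 1.6%, and almost none of it is left after the incubation. Compound 2 in this assay returns "below limit of detection" (no number reported), an entry without a number. Among the measured compounds shown here, compound 1 is therefore the only compound of the series with a number, and that number sits at the low end of the scale; the remaining entry offers no number to rank it against.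

Compound 3 `O=C(NCc1ccc(S(=O)(=O)c2ccccc2)cc1)c1ccc2nccn2c1` is the next compound to be run in this assay. It differs from compound 1 in one place: a group of 9 heavy atoms (7 carbon, 2 nitrogen; one five-membered aromatic ring with 2 hetero atoms, one six-membered aromatic ring with 1 hetero atom) in place of a group of 9 heavy atoms (7 carbon, 1 nitrogen, 1 sulfur; one five-membered aromatic ring with 1 hetero atom, one six-membered aromatic ring with 1 hetero atom), on a carbonyl carbon. For the measured compounds named here, no step between two measured compounds is available in this assay, so the size of this change cannot be read from a precedent. Given that compound 1 gives 1.6%, a value at the low end of the scale leaves room mainly upward, and the expected step is a number 3.4 percentage points higher from compound 1 to compound 3 (within the scatter), most likely within the scatter. Compound 3 is estimated at 5%, with a range of 0.5% to 25%.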

Compound 3, percent of the compound remaining: 18%
Beside the measured number, compound 3's estimate is 13 percentage points below it, and the stated range covers the measured number.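

In this assay, the group on the carbonyl carbon gives the series its first readable comparison: replacing the group with a five-membered aromatic ring with 1 hetero atom by the group with a five-membered aromatic ring with 2 hetero atoms gives a number 16.4 percentage points higher from compound 1 to compound 3 (beyond the scatter). The heavy-atom count and the numbers of hydrogen-bond donors and acceptors are the same in the two groups, and the rest of the molecule is unchanged, so this place can move the read-out without a change in those counts, although compound 3 at 18% still stays in the lower part of the scale. No measured information bears on why the read-out moves at this position.

Steps to compound 2 cannot be read, since its entry carries no number. This single step does not separate the loss of sulfur from the different arrangement of the ring nitrogen atoms, and it leaves open whether an amine or a carboxylic acid on the entering group would raise or lower the percentage remaining.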